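The source may report more compounds than this note shows. Statements on the series, on what has been measured and on what is new or still open speak of the compounds shown alone.

Three measured compounds share one core and have been tested in the same way. Compound 1 `Cc1cc(C)nc(NS(=O)(=O)c2ccc(/N=C/c3c(Cl)c4ccccc4oc3=O)cc2)n1` gives 170 nM in a functional assay on B16-F10 cells (Mus musculus) for cytotoxicity, read by CCK-8 assay, with a stated time of 48 h; a lower number here means a stronger inhibitor, a higher number a weaker inhibitor. Compound 3 `Cc1ccnc(NS(=O)(=O)c2ccc(/N=C/c3c(Cl)c4ccccc4oc3=O)cc2)n1` gives 230 nM, and compound 2 `Cc1cc(NS(=O)(=O)c2ccc(/N=C/c3c(Cl)c4ccccc4oc3=O)cc2)no1` gives 270 nM. Compound 2 thus holds the highest of the three numbers, yet its nearest neighbour is compound 3 (a 1.2-fold lower number from compound 2 to compound 3 (0.07 log units; within the scatter)) and its furthest is compound 1 (a 1.6-fold higher number from compound 1 to compound 2 (0.20 log units; within the scatter)), so all three sit together within the scatter and none can be set apart from the others.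

Compound 4 `Cc1ccc2oc(=O)c(/C=N/c3ccc(S(=O)(=O)Nc4cc(C)on4)cc3)c(Cl)c2c1` has not yet been measured. It differs from compound 2 by methyl in place of hydrogen on an aromatic carbon. Within the data shown here, the only measured step of the same kind is a 1.4-fold higher number from compound 1 to compound 3 (0.13 log units; within the scatter), in which hydrogen replaces methyl on an aromatic carbon of the 4,6-dimethylpyrimidin-2-yl group rather than of the fused system; that step stayed within the scatter. Among the measured compounds shown here, no measured step touches the fused system itself, so nothing among the measured compounds points to a large effect there. On this basis a change that stays within the scatter in this assay is expected for compound 4, in no particular direction, and the expected step is no change at the digits printed from compound 2 to compound 4 (within the scatter). Compound 4 is therefore expected to give 270 nM, with a range from 130 nM to 560 nM.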

Compound 4, half-maximal inhibitory concentration: 250 nM
Estimate against measurement, compound 4: 1.1-fold (0.03 log units) above; measured number inside the range.
By their numbers in this assay, from the lowest: compounds 1, 3, 4 and 2 (each within the scatter of the next).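

In this assay, among these compounds, the step at the fused system, a 1.1-fold lower number from compound 2 to compound 4 (0.03 log units; within the scatter), is the first measured change on that part of the shared core, and it shows that a methyl on this aromatic carbon, meta to a fused ring and para to a fused ring, leaves compound 4 indistinguishable from compound 2. Until now, the exchange of hydrogen and methyl had been read only on the group carried by the sulfonamide nitrogen, and it can now be read at a second place, with the two readings in agreement: the same change on two cores in this assay, a 1.4-fold higher number (0.13 log units; within the scatter) from compound 1 to compound 3 and a 1.1-fold higher number (0.03 log units; within the scatter) from compound 4 to compound 2, 1.3-fold (0.10 log units) apart, within the scatter of two such steps. The fused system therefore joins that group as a place where this single change gives no step beyond the scatter, although this rests on one pair of compounds at each place.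

The compounds shown leave open whether any group other than methyl at this position, such as an amine, a carboxylic acid or a longer chain like n-butyl, would give a step beyond the scatter. They also leave open whether a methyl on the other aromatic carbons of this ring would behave in the same way.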